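The source may report more compounds than this note shows. Statements on the series, on what has been measured and on what is new or still open speak of the compounds shown alone.

Measured in a physicochemical assay for solubility; on this read-out higher numbers stand for higher solubility and lower numbers for lower solubility:
- Compound 1 `O=C(Nc1c(Cl)cc([N+](=O)[O-])cc1Cl)c1cc(Cl)ccc1O`: 53 ug/mL
- Compound 2 `O=C(Nc1ccc(F)cc1Cl)c1cc(Cl)ccc1O`: 1.2 ug/mL

Compound 2 holds the lower of the two numbers, at 1.2 ug/mL, and compound 1 stands at 53 ug/mL. The gap between them lies well outside the usual scatter. Compound 3 `O=C(Nc1c(Cl)cc(F)cc1Cl)c1cc(Cl)ccc1O` departs from compound 2 by a single change, chloro in place of hydrogen on an aromatic carbon, ortho to a large group. For the measured compounds named here, no measured pair shows this change on its own, so any expectation remains loose. A modest rise in this assay is expected, small beside the gap between the two measured compounds and only slightly beyond the scatter. Going by the values given here, the upward lean rests on compound 1 at 53 ug/mL, the only higher number available. The expected step is a 2.5-fold higher number from compound 2 to compound 3 (0.40 log units; beyond the scatter). For compound 3 the estimated value is 3 ug/mL, with a range of 0.6 ug/mL to 15 ug/mL.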

Compound 3, solubility: > 49 ug/mL
Compound 3: only a limit was reported; the forecaster's own chance of this, stated with the estimate: 5%; at least 16-fold (1.21 log units) between middle value and limit.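

In this assay compound 3 gives > 49 ug/mL, a limit and not a number. Chloro in place of hydrogen on an aromatic carbon, ortho to a large group, comes with an at least 40-fold higher number from compound 2 to compound 3 (1.61 log units; beyond the scatter), so one added atom at this position goes with a large step beyond the scatter, a single-change reading that the two earlier compounds, which differ in more than one place, could not give. The step for fluoro in place of nitro on an aromatic carbon, from compound 1 to compound 3, cannot be read: the limit of > 49 ug/mL in this assay, at which 1 of the 3 values shown sits.

The compounds shown leave open whether this step belongs to chloro itself or would also come with a methyl group or a bromo group on the same carbon. They also leave open how compound 3 truly stands against compound 1 in this assay.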